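Pyridin-2-yl for phenyl: working notes on compound 4

The source may hold more compounds than are shown below. What is called first, only, known or untested is meant among the compounds shown, and "the series" means these compounds.

- Compound 1 `Cn1cc(C(=O)Nc2ccc(-c3ccccc3)c(C(F)(F)F)c2)c(=O)c2ccncc21` gives < 1 ug/mL as a limit of the assay.
- Compound 2 `Cn1cc(C(=O)Nc2cnc(-c3ccccc3)c(C(F)(F)F)c2)c(=O)c2ccccc21` gives < 1 ug/mL as a limit of the assay.
- Compound 3 `Cn1cc(C(=O)Nc2ccc(-c3ccccc3)c(C(F)(F)F)c2)c(=O)c2ccccc21` gives 1.3 ug/mL as a measured number.

Among the compounds with values here, in a physicochemical assay for solubility, at pH 7.4 (on this read-out higher numbers stand for higher solubility and lower numbers for lower solubility), compound 3 gives 1.3 ug/mL, the only actual number in the set. The other two results rest on (the limit of < 1 ug/mL in this assay, at which 2 of the 3 values shown sit), and neither can be read as a number.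

Compound 4 `Cn1cc(C(=O)Nc2ccc(-c3ccccn3)c(C(F)(F)F)c2)c(=O)c2ccccc21` is the next compound to be measured. It carries pyridin-2-yl in place of phenyl on an aromatic carbon, ortho to a trifluoromethyl group (pyridin-2-yl in place of phenyl on an aromatic carbon).

No pair among the measured compounds differs in one place only, so nothing yet sizes a change of this kind in this assay within the series. The expectation therefore rests on compound 3 at 1.3 ug/mL as its sole anchor, and no step beyond the usual scatter is expected in either direction. The estimated change is a 1.2-fold higher number from compound 3 to compound 4 (0.06 log units; within the scatter) on this reading. A result reported only as a limit remains a real possibility. For compound 4 the expected value is 1.5 ug/mL, with an estimated range from 0.6 ug/mL to 5 ug/mL across repeat measurements.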

Compound 4, solubility: 12 ug/mL
Beside the measured number, compound 4's estimate is 8.0-fold (0.90 log units) below it, and the stated range ends below it.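

In this assay, within the data shown here, pyridin-2-yl in place of phenyl, on the aromatic carbon ortho to a trifluoromethyl group, gives a 9.2-fold higher number from compound 3 to compound 4 (0.97 log units; beyond the scatter), the first single-place step that can be sized. The two groups have 6 heavy atoms each and differ by one ring atom, a carbon exchanged for a nitrogen, so this one exchange at this position separates the two values. Steps to the two compounds held at the limit cannot be read: the limit of < 1 ug/mL in this assay, at which 2 of the 4 values shown sit.

The compounds shown give no measured property that accounts for the step, and a single pair in this assay cannot say whether the same exchange would carry over to other members of the series. They also leave open how pyridin-3-yl, pyridin-4-yl or a phenyl ring bearing an amine or a carboxylic acid would read at this carbon, and so whether the position of the ring nitrogen matters.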